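The source may hold more compounds than are shown below. What is called first, only, known or untested is meant among the compounds shown, and "the series" means these compounds.

In an ADME assay on L6 cells (Rattus norvegicus) for cytotoxicity, read by resazurin assay, with a stated time of 72 h (a higher number here means that more compound is needed for the effect, a lower number that less compound is needed), three compounds have been measured:
compound 1 `CCOC(=O)C1=C(C)N/C(=C/c2cc(C)n(-c3cccc(O)c3)c2C)C1=O` with 69000 nM;
compound 2 `CCOC(=O)C1=C(C)N/C(=C/c2cc(C)n(-c3ccc([S+](C)[O-])cc3)c2C)C1=O` with 220000 nM;
compound 3 `CCOC(=O)C1=C(C)N/C(=C/c2cc(C)n(-c3ccc(SC)cc3)c2C)C1=O` with 54000 nM.

Compound 3 gives the lowest of the three numbers, though one of its two gaps, a 1.3-fold lower number from compound 1 to compound 3 (0.11 log units; within the scatter), lies within the scatter, while the other, a 4.1-fold lower number from compound 2 to compound 3 (0.61 log units; beyond the scatter), is modest. Compound 4 `CCOC(=O)C1=C(C)N/C(=C/c2cc(C)n(-c3ccncc3)c2C)C1=O` carries pyridin-4-yl in place of 4-(methylsulfanyl)phenyl on an aromatic nitrogen. For the measured compounds named here, no measured step exchanges this same group, so the bearing is indirect: a 3.2-fold higher number from compound 1 to compound 2 (0.50 log units; beyond the scatter) and a 4.1-fold lower number from compound 2 to compound 3 (0.61 log units; beyond the scatter) show that changing the aromatic group on this nitrogen moves this assay only modestly. A step of a 1.5-fold higher number from compound 3 to compound 4 (0.17 log units; within the scatter) is therefore expected for compound 4, within or close to the scatter. Compound 4 is estimated at 80000 nM, with a range from 30000 nM to 250000 nM.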

Compound 4, half-maximal effective concentration: 100000 nM
The estimate for compound 4 lay 1.3-fold (0.10 log units) below the measured number; the measured number falls inside the stated range.
By their numbers in this assay, from the lowest: compounds 3, 1 and 4 (each within the scatter of the next); then compound 2.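

In this assay, the ring on the aromatic nitrogen can carry a ring nitrogen, as pyridin-4-yl does, without a shift beyond the scatter from either carbon-only ring in compound 3 or compound 1 (a 1.9-fold higher number from compound 3 to compound 4 (0.27 log units; within the scatter); a 1.4-fold higher number from compound 1 to compound 4 (0.16 log units; within the scatter)). Compound 2 alone stays apart from this group, by a modest margin (a 2.2-fold lower number from compound 2 to compound 4 (0.34 log units; beyond the scatter)).

From the compounds shown here alone, whether an amine or a carboxylic acid on this ring would move the number further remains open. Nothing measured here explains these steps.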